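The source may hold more compounds than are shown below. What is called first, only, known or untested is meant among the compounds shown, and "the series" means these compounds.

Measured so far:
compound 1, `CC/N=C(/NC#N)NCCCCCCn1nc(-c2ccccc2)ccc1=O`: 29.1%
compound 2, `C/N=C(\S)NCCCCCCn1nc(-c2ccccc2)ccc1=O`: 22.2%

In a functional assay on the whole organism with Rattus norvegicus as the target, at a dose of 100 mg/kg (a lower number here means less inhibition, a higher number more inhibition at the dose given (going by the name of the read-out)), compound 1 gives 29.1% and compound 2 gives 22.2%. The two numbers lie within the scatter of each other, the single recorded step being a number 6.9 percentage points lower from compound 1 to compound 2 (within the scatter), so on the numbers shown compound 2 stands level with compound 1 rather than apart from it.

Compound 3, `CC/N=C(/NC#N)NCCCCCn1nc(-c2ccccc2)ccc1=O`, is not yet measured. Against compound 2 the change is a group of 8 heavy atoms (4 carbon, 4 nitrogen; no ring) in place of a group of 6 heavy atoms (3 carbon, 2 nitrogen, 1 sulfur; no ring), on a saturated chain carbon, five bonds along the chain from an aromatic nitrogen. Among the measured compounds shown here, the chain end of compound 3 is that of compound 1, so the step of a number 6.9 percentage points lower from compound 1 to compound 2 (within the scatter) is the one measured step that bears on it: exchanging the chain end moved the read-out only within the scatter. For the measured compounds named here, the shorter chain of compound 3 has no measured counterpart, and nothing beyond the scatter is assumed for it. The step of a number 5.8 percentage points higher from compound 2 to compound 3 (within the scatter) is therefore expected to be small and within the scatter, with compound 3 expected close to the number of compound 1.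

Compound 3 is estimated at 28%, with a range from 16% to 40%.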

Compound 3, a percentage reported as inhibition, in the whole organism at one dose (the size of the read-out at that dose, not a potency): 48.2%
Estimate against measurement, compound 3: 20.2 percentage points below; measured number outside the range, above it.
By their numbers in this assay, from the lowest: compounds 2 and 1 (each within the scatter of the next); then compound 3.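

In this assay, among the compounds shown here, the chain now counts at this position: with the chain end kept, the shorter chain gives a number 19.1 percentage points higher from compound 1 to compound 3 (beyond the scatter), beyond the scatter, whereas the one earlier step, a number 6.9 percentage points lower from compound 1 to compound 2 (within the scatter), stayed within it. The step of a number 26 percentage points higher from compound 2 to compound 3 (beyond the scatter) is also beyond the scatter, but it changes both the chain end and the chain, so it cannot be assigned to either change alone. Nothing at hand gives a reason for the higher number at the shorter chain.

Open, as far as these compounds go, is whether the number keeps rising as the chain is shortened further or peaks at the chain of compound 3, which a butyl chain carrying the same chain end would test, and whether the sulfur-bearing chain end of compound 2 would follow the same course on the shorter chain. Also open is how a urea or a guanidine at the chain end would compare on the chain of compound 3, and whether the order of these compounds would hold at other doses.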